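The compounds below may be only part of what the source reports. "The series", "measured", "known", "first", "only" and "open" are said of these compounds alone.

Compound 1 `CC1=CC(=O)OC(CSc2nc(-c3ccccc3)c(-c3ccccc3)[nH]2)C1`: 200 nM
Compound 2 `O=C1CCCC(CSc2nc(-c3ccccc3)c(-c3ccccc3)[nH]2)O1`: 740 nM
Compound 3 `O=C1CCC(CSc2nc(-c3ccccc3)c(-c3ccccc3)[nH]2)N1`: 360 nM

These three share one core and differ only in the ring attached to the saturated chain carbon bound to a sulfur. In an assay on microsomes from liver for inhibition of sterol O-acyltransferase 1 (Rattus norvegicus) (a higher number here means a weaker inhibitor, a lower number a stronger inhibitor), compound 3 stands second highest of the three: its number lies within the scatter of compound 1, while one measured step is a 2.1-fold lower number from compound 2 to compound 3 (0.31 log units; beyond the scatter). Compound 4 `c1ccc(-c2nc(SCC3OCCCO3)[nH]c2-c2ccccc2)cc1` changes that same ring once more: a group of 6 heavy atoms (4 carbon, 2 oxygen; one six-membered non-aromatic ring with 2 hetero atoms) in place of a group of 6 heavy atoms (4 carbon, 1 nitrogen, 1 oxygen; one five-membered non-aromatic ring with 1 hetero atom), on a saturated chain carbon bound to a sulfur. Within the data shown here, the steps that bear on this place were a 1.8-fold higher number from compound 1 to compound 3 (0.26 log units; within the scatter) and a 3.7-fold higher number from compound 1 to compound 2 (0.57 log units; beyond the scatter), so ring swaps here have moved the number only modestly. A modest shift in either direction, or none beyond the scatter, is therefore expected. Compound 4 is expected to give about 450 nM, with a range from 180 nM to 1200 nM. That expectation corresponds to a 1.3-fold higher number from compound 3 to compound 4 (0.10 log units; within the scatter).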

Compound 4, half-maximal inhibitory concentration: 180 nM
Compound 4: the middle estimate sits 2.5-fold (0.40 log units) above what was measured, within the range that was stated.
By their numbers in this assay, from the lowest: compounds 4, 1 and 3 (each within the scatter of the next); then compound 2.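

In this assay the ring on the saturated chain carbon bound to a sulfur need not hold a carbonyl, as all earlier rings did: a 2.0-fold lower number from compound 3 to compound 4 (0.30 log units; within the scatter) and a 1.1-fold lower number from compound 1 to compound 4 (0.05 log units; within the scatter) both stay within the scatter. Six-membered rings do not all read alike, since the two that differ here show a 4.1-fold lower number from compound 2 to compound 4 (0.61 log units; beyond the scatter) as their step. As far as these compounds go, whether an open chain, an amine or a carboxylic acid at this place would keep such a number remains open. No measurement at hand explains the gap between these rings.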